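A Third Methoxy on the Ketone Aryl of Compound 2

The source may hold more compounds than are shown below. What is called first, only, known or untested is meant among the compounds shown, and "the series" means these compounds.

Compound 2 `COc1ccc(C(=O)/C=C/c2cc(-c3cc(OC)c(OC)c(OC)c3)n[nH]2)cc1OC` is one of three compounds sharing a core that were tested in a functional assay on OVCAR-5 cells (Homo sapiens) for inhibition, read by sulforhodamine B assay, with a stated time of 48 h; a higher number here means a weaker inhibitor of growth, a lower number a stronger inhibitor of growth; in this assay compound 2 gives 3030 nM. Compound 3 `COc1ccc(C(=O)/C=C/c2cc(-c3cc(OC)c(OC)c(OC)c3)n[nH]2)cc1` gives 3780 nM in this assay. Compound 1 `COc1cc(-c2cc(/C=C/C(=O)c3ccc(Cl)c(Cl)c3)[nH]n2)cc(OC)c1OC` reaches only > 100000 nM in this assay, which is a limit of the assay rather than a number. Of the two numbers, compound 2 has the lower one, and its nearest neighbour is compound 3, with a 1.2-fold higher number from compound 2 to compound 3 (0.10 log units; within the scatter). The exchanges of the 3,4-dichlorophenyl group of compound 1 gave large steps, an at least 33-fold lower number from compound 1 to compound 2 (1.51 log units; beyond the scatter) and an at least 26-fold lower number from compound 1 to compound 3 (1.42 log units; beyond the scatter), both measured from the limit of > 100000 nM in this assay, at which 1 of the 3 values shown sits.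

Compound 4 `COc1cc(C(=O)/C=C/c2cc(-c3cc(OC)c(OC)c(OC)c3)n[nH]2)cc(OC)c1OC` differs from compound 2 by methoxy in place of hydrogen on an aromatic carbon. Among the measured compounds shown here, the step that bears on this change is the one between compound 2 and compound 3, where one methoxy on the same ring was removed and the number stayed within the scatter. Adding one methoxy is therefore expected to change little as well: the expected step from compound 2 to compound 4 is a 1.1-fold higher number from compound 2 to compound 4 (0.02 log units; within the scatter), within the scatter. Compound 4 is estimated to give 3200 nM in this assay, with a range from 1200 nM to 9000 nM.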

Compound 4, concentration for total growth inhibition: 3120 nM
Compound 4: the middle estimate sits 1.0-fold (0.01 log units) above what was measured, and the stated range covers the measured number.
By their numbers in this assay, from the lowest: compounds 2, 4 and 3 (each within the scatter of the next). At a limit, above all of these: compound 1.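

The earlier compounds shown here showed only a methoxy being taken off this ring; compound 4 shows one being added, on an aromatic carbon ortho to a methoxy group and meta to a large group, and the outcome in this assay is a 1.0-fold higher number from compound 2 to compound 4 (0.01 log units; within the scatter). Starting from compound 2, then, both removing a methoxy from this ring and adding one leave the number within the scatter. Replacing the whole ring substitution pattern matters far more, as the exchange of the 3,4-dichlorophenyl group gave an at least 33-fold lower number from compound 1 to compound 2 (1.51 log units; beyond the scatter).

Still open, going by these compounds, is whether a different group at this position, such as an amine, a carboxylic acid or a longer chain, would also leave the number unchanged. Nothing shown here explains why the added methoxy makes so little difference.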